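Chain extension from compound 3 to compound 4

The compounds below may be only part of what the source reports. "The series", "measured", "known", "first", "only" and "open" are said of these compounds alone.

In a functional assay on A549 cells (Homo sapiens) for antiproliferative activity, read by MTT assay, with a stated time of 96 h (on this read-out higher numbers stand for weaker inhibition of growth and lower numbers for stronger inhibition of growth), compound 3 (`O=C(CCCNC(=O)c1cc(-c2ccc(F)cc2)[nH]n1)NO`) gives > 100000 nM, which is a limit and not a number. Its place is the limit of > 100000 nM in this assay, at which 1 of the 3 values shown sits, and no exact rank can be given.

On the same read-out compound 2 (`O=C(CCNC(=O)c1cc(-c2ccc(F)cc2)[nH]n1)NO`) gives 46900 nM and compound 1 (`Cc1ccc(-c2cc(C)nn2Cc2ccc(C(=O)NO)cc2)cc1`) gives 12400 nM as the two true numbers.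

The change to compound 4 (`O=C(CCCCCCNC(=O)c1cc(-c2ccc(F)cc2)[nH]n1)NO`) is 3-(hydroxycarbamoyl)propyl in place of hydroxycarbamoyl on a saturated chain carbon, three bonds along the chain from an amide-type nitrogen and puts 3-(hydroxycarbamoyl)propyl in place of hydroxycarbamoyl.

For the measured compounds named here, the only measured step on this chain is an at least 2.1-fold higher number from compound 2 to compound 3 (0.32 log units; beyond the scatter), a modest one for a shorter extension. It points toward weaker inhibition of growth, but one step that ends at a limit sets no trend for a longer chain.

Any number for compound 4 would have to lie under the limit. Compound 2 at 46900 nM is the nearest number on this chain. The expected at least 3.3-fold lower number from compound 3 to compound 4 (0.52 log units; beyond the scatter) is toward stronger inhibition and moderate in size, though a result at the limit stays possible.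

The estimated value for compound 4 is 30000 nM, with 6000 nM to 100000 nM as the expected range.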

Compound 4, concentration for 50% growth inhibition: 1980 nM
Beside the measured number, compound 4's estimate is 15-fold (1.18 log units) above it; the whole stated range lies above it.
By their numbers in this assay, from the lowest: compound 4; then compound 1; then compound 2. At a limit, above all of these: compound 3.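

In this assay the longer chain turns the direction seen so far around: the change brings an at least 50-fold lower number from compound 3 to compound 4 (1.70 log units; beyond the scatter), and the comparison with the shortest chain gives a 24-fold lower number from compound 2 to compound 4 (1.37 log units; beyond the scatter), both large steps toward stronger inhibition of growth. The earlier step, an at least 2.1-fold higher number from compound 2 to compound 3 (0.32 log units; beyond the scatter), ran the other way, so across these three compounds inhibition does not follow chain length in one direction, and compound 3 goes against any steady gain with length. The figure for compound 3 is a limit and not a number, so the first of these steps has only a minimum size: the limit of > 100000 nM in this assay, at which 1 of the 4 values shown sits.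

For the compounds shown here, whether a still longer chain than the one in compound 4 would add to the gain or lose it stays open. Also open, on these data alone, is whether the gain survives with a carboxylic acid in place of the hydroxycarbamoyl end.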